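The compounds below may be only part of what the source reports. "The series", "measured", "known", "first", "only" and "open" are said of these compounds alone.

Compound 1 `CC(=O)Nc1ccc2oc(-c3cccc(C(F)(F)F)c3)cc(=O)c2c1`: 50000 nM
Compound 2 `COc1cccc(-c2oc3ccc(NC(C)=O)cc3c(=O)c2O)c1`: 50000 nM
Compound 3 `CC(=O)Nc1ccc2oc(-c3ccc(F)cc3)c(O)c(=O)c2c1`: 26000 nM

Among the compounds with values here, in an ADME assay on THP-1 cells (Homo sapiens) for cytotoxicity, read by flow cytometry and propidium iodide staining, with a stated time of 72 h (on this read-out higher numbers stand for weaker inhibition and lower numbers for stronger inhibition), compound 2 gives 50000 nM, level with compound 1, and no measured compound stands beyond the scatter from it. Compound 4 `CC(=O)Nc1ccc2oc(-c3cccc(C(F)(F)F)c3)c(O)c(=O)c2c1` has trifluoromethyl in place of methoxy on an aromatic carbon. Within the data shown here, the one measured step that swaps a group on an aromatic carbon, a 1.9-fold lower number from compound 2 to compound 3 (0.28 log units; within the scatter), stays within the scatter. Compound 1 also carries trifluoromethyl and gives 50000 nM. No step beyond the scatter is therefore expected in this assay, and the estimated change is a 1.2-fold lower number from compound 2 to compound 4 (0.08 log units; within the scatter). Compound 4 is expected at 42000 nM, within an estimated range of 20000 nM to 70000 nM.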

Compound 4, half-maximal inhibitory concentration: 1000 nM
Compound 4: the middle estimate sits 42-fold (1.62 log units) above what was measured; measured number below the stated range.
By their numbers in this assay, from the lowest: compound 4; then compounds 3, 1 and 2 (each within the scatter of the next).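

In this assay, the aromatic carbon carrying methoxy in compound 2 proves sensitive, since trifluoromethyl there gives a large step (a 50-fold lower number from compound 2 to compound 4 (1.70 log units; beyond the scatter)). Hydroxy in place of hydrogen on an aromatic carbon gives an equally large step (a 50-fold lower number from compound 1 to compound 4 (1.70 log units; beyond the scatter)), so among these compounds the low number appears only where trifluoromethyl and hydroxy occur together, as in compound 4. Nothing measured here gives a reason for this. From the compounds shown here alone, whether a nitrile or an amine at the trifluoromethyl position would keep the low number remains open. So does whether a methyl ether in place of the hydroxy would keep it.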